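Sulfonyl pyridine variation on a fluorinated pyrrole series

The source may hold more compounds than are shown below. What is called first, only, known or untested is meant among the compounds shown, and "the series" means these compounds.

Compound 2 `CNCc1cn(S(=O)(=O)c2cccc(OC)n2)c(-c2cccnc2F)c1F` gives 98% in a functional assay on the whole organism (strain Jcl:Sprague-Dawley) for inhibition, with Rattus norvegicus as the target, with stated times of 3 min and 3 h, at a dose of 1 mg/kg by the intravenous route (a higher number here means more inhibition at the dose given (going by the name of the read-out), a lower number less inhibition), the highest of the two numbers recorded; the nearest entry is compound 1 `CNCc1cc(-c2cccnc2F)n(S(=O)(=O)c2ccccn2)c1`, which gives 81% in this assay, a gap beyond the scatter. Compound 3 `CNCc1cn(S(=O)(=O)c2cccnc2Cl)c(-c2cccnc2F)c1F` stands at "not determined" (no result reported) in this assay, so no number is available for it. Compound 4 `CNCc1cn(S(=O)(=O)c2cnccc2C)c(-c2cccnc2F)c1F` differs from compound 2 by 4-methylpyridin-3-yl in place of 6-methoxypyridin-2-yl on a sulfonyl sulfur. Among the measured compounds shown here, no pair of measured compounds isolates this change, so the expected step rests only on compound 2 at 98% and the general level of the series. A small downward step, at or near the edge of the scatter, is expected, a number 10 percentage points lower from compound 2 to compound 4 (within the scatter). Compound 4 is estimated to give 88% in this assay, with a likely range from 65% to 99%.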

Compound 4, a percentage reported as inhibition, in the whole organism at one dose (the size of the read-out at that dose, not a potency): 98%
Compound 4: middle estimate off by 10 percentage points, on the low side; low and high end bracket the measured number.
By their numbers in this assay, from the lowest: compound 1; then compounds 2 and 4 (each within the scatter of the next).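

Among the compounds shown here, on the sulfonyl sulfur, 4-methylpyridin-3-yl in place of 6-methoxypyridin-2-yl gives no change at the digits printed from compound 2 to compound 4 (within the scatter) in this assay, the only step readable at this position. The entering group carries no oxygen, so a methoxy group is not required for this read-out at this dose. As the read-out comes from a single dose, the step says nothing about potency.

On these data alone, whether an unsubstituted phenyl, or a pyridine bearing a carboxylic acid, on the sulfonyl sulfur holds the read-out remains open. Nothing available accounts for the flat step.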